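Pyridin-3-yl Replaces the Trifluoromethylphenyl Group on a Shared Core

A few compounds are considered here, and "the series" means these few. Any claim that something is new, unique, unknown or untested is made for them only; others in the source may bear on it.

Compound 1 `Cc1c(C2CC2)nc2ccc(-n3ccc(OCc4ccc(F)cc4)cc3=O)cn12` gives 28 nM in an assay on CHO cells for displacement of a labelled ligand from melanin-concentrating hormone receptor 1 (Rattus norvegicus), read by scintillation counting, with a stated time of 1 h; a lower number here means a stronger inhibitor, a higher number a weaker inhibitor.
Compound 2 `Cc1c(C2CC2)nc2ccc(-n3ccc(OCc4ccc(C(C)C)cc4)cc3=O)cn12` gives 240 nM in this assay.
Compound 3 `Cc1c(C2CC2)nc2ccc(-n3ccc(OCc4ccc(C(F)(F)F)cc4)cc3=O)cn12` gives 82 nM in this assay.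

Compound 3 stands second highest of the three numbers in this assay: compound 2 is nearest, with a 2.9-fold lower number from compound 2 to compound 3 (0.47 log units; beyond the scatter), and compound 1 is furthest, with a 2.9-fold higher number from compound 1 to compound 3 (0.47 log units; beyond the scatter). The new compound 4 `Cc1c(C2CC2)nc2ccc(-n3ccc(OCc4cccnc4)cc3=O)cn12` differs from compound 3 by pyridin-3-yl in place of 4-(trifluoromethyl)phenyl on a saturated chain carbon bound to an oxygen on an aromatic ring. None of the three measured steps bears directly on this change; all of them vary only the group on the phenyl ring, and the largest, an 8.6-fold higher number from compound 1 to compound 2 (0.93 log units; beyond the scatter), is modest. Replacing the whole ring with pyridin-3-yl is therefore unsupported by any measured step, and a modest change in either direction would not surprise. Compound 4 is estimated at 150 nM, with a range from 40 nM to 600 nM, which means an expected step of a 1.8-fold higher number from compound 3 to compound 4 (0.26 log units; within the scatter).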

Compound 4, half-maximal inhibitory concentration: > 1000 nM
Compound 4: a limit, no number; the forecaster's own chance of this, stated with the estimate: 5%; middle value at least 6.6-fold (0.82 log units) away from the limit.
By their numbers in this assay, from the lowest: compound 1; then compound 3; then compound 2. At a limit, above all of these: compound 4.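

For compound 4 the reading is a limit of the assay, not a number: the limit of > 1000 nM in this assay, at which 1 of the 4 values shown sits. Pyridin-3-yl in place of the substituted phenyl rings gives an at least 35-fold higher number from compound 1 to compound 4 (1.55 log units; beyond the scatter), an at least 12-fold higher number from compound 3 to compound 4 (1.08 log units; beyond the scatter) and an at least 4.1-fold higher number from compound 2 to compound 4 (0.61 log units; beyond the scatter). For the compounds shown here, the earlier compounds changed only the group on the phenyl ring and all gave numbers, whereas exchanging the ring itself gives the first large steps at this position.

The compounds shown do not separate the ring nitrogen from the loss of the phenyl group's substituent. Unsubstituted phenyl, or a fluoro-bearing pyridine, would address that.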